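The source may hold more compounds than are shown below. What is called first, only, known or untested is meant among the compounds shown, and "the series" means these compounds.

In a functional assay on A-375 cells (Homo sapiens) for antiproliferative activity (on this read-out lower numbers stand for stronger inhibition and higher numbers for weaker inhibition), compound 1 `O=C(Nc1ccc(-c2cscn2)cc1)[C@H]1CCCN(Cc2ccc(F)c(F)c2)C1`, which carries a thiazole ring, gives 190 nM, and compound 2 `O=C(Nc1ccc(-c2ccncc2)cc1)C1CCCN(Cc2ccc(F)c(F)c2)C1`, which carries pyridin-4-yl, gives 600 nM. Compound 3 `O=C(Nc1ccc(-c2c[nH]cn2)cc1)C1CCCN(Cc2ccc(F)c(F)c2)C1` gives > 20000 nM, which is a limit of the assay and not a number. Going by these compounds, this places compound 3 at the limit of > 20000 nM in this assay, at which 1 of the 3 values shown sits, so how weak it truly is remains unknown.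

Compound 4 `O=C(Nc1ccc(-c2cccs2)cc1)C1CCCN(Cc2ccc(F)c(F)c2)C1` carries thiophen-2-yl in place of 1H-imidazol-4-yl on an aromatic carbon. Among the measured compounds shown here, one measured step bears directly on this swap. It is an at least 33-fold higher number from compound 2 to compound 3 (1.52 log units; beyond the scatter), a large change that lies beyond the scatter and involves the same group that now leaves. For the measured compounds named here, compound 4 has not been measured, and a thiophene has no direct precedent in this small set. Even so, leaving the imidazole behind should reverse much of that loss, bringing the number back towards those of compound 1 and compound 2. The expected change is a large drop, towards stronger inhibition: an at least 50-fold lower number from compound 3 to compound 4 (1.69 log units; beyond the scatter). For compound 4 the estimated value is 400 nM, with an expected range from 100 nM to 2000 nM.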

Compound 4, half-maximal inhibitory concentration: 390 nM
For compound 4 the middle estimate is 1.0-fold (0.01 log units) above the measured one, within the range that was stated.
By their numbers in this assay, from the lowest: compound 1; then compounds 4 and 2 (each within the scatter of the next). At a limit, above all of these: compound 3.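

In this assay, the result shows that a five-membered aromatic ring at this position does not by itself abolish activity: replacing 1H-imidazol-4-yl with thiophen-2-yl, which has the same number of heavy atoms, gives an at least 51-fold lower number from compound 3 to compound 4 (1.70 log units; beyond the scatter). Thiophen-2-yl and pyridin-4-yl cannot be told apart here, since their difference is a 1.5-fold lower number from compound 2 to compound 4 (0.19 log units; within the scatter), so this position accepts both a five-membered and a six-membered aromatic ring. The size of the first step remains uncertain, as the value for compound 3 is a limit and not a number: the limit of > 20000 nM in this assay, at which 1 of the 4 values shown sits.

The swap removes the hydrogen-bond donor and also exchanges two nitrogens for one sulfur, so these compounds cannot show which of these changes matters. Going by these compounds, a 1-methylimidazol-4-yl group or a plain phenyl ring at this position would help separate the two, and both remain open here.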